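The compounds below may be only part of what the source reports. "The series", "measured", "known", "first", "only" and "open" are said of these compounds alone.

Compound 1 `Oc1cccc(-c2cc(-c3ccsc3)nc(-c3cccc(Cl)c3)c2)c1` gives 3540 nM in a functional assay on T47D cells (Homo sapiens) for cytotoxicity, read by CCK-8 assay and cell counting, with a stated time of 2 days; on this read-out lower numbers stand for stronger inhibition and higher numbers for weaker inhibition. Compound 2 `Oc1cccc(-c2cc(-c3ccsc3)nc(-c3ccccc3Cl)c2)c1` gives 2440 nM, and the step of a 1.5-fold lower number from compound 1 to compound 2 (0.16 log units; within the scatter) leaves the two within the scatter of each other, so compound 1 stands apart from nothing yet. Compound 3 `Oc1cccc(-c2cc(-c3ccccc3)nc(-c3cccc(Cl)c3)c2)c1` differs from compound 1 by phenyl in place of thiophen-3-yl on an aromatic carbon. Going by the values given here, no measured step touches the thiophen-3-yl group; the single step from compound 1 to compound 2 concerns the chlorophenyl group and was within the scatter, so it offers no guidance here. Nothing beyond the scatter is expected in this assay. Compound 3 is estimated at 3500 nM, with a range of 1400 nM to 9000 nM, an expected step of a 1.0-fold lower number from compound 1 to compound 3 (0.00 log units; within the scatter).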

Compound 3, half-maximal inhibitory concentration: 3700 nM
Estimate against measurement, compound 3: 1.1-fold (0.02 log units) below; measured number inside the range.
By their numbers in this assay, from the lowest: compounds 2, 1 and 3 (each within the scatter of the next).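

In this assay, phenyl in place of thiophen-3-yl on the aromatic carbon next to the ring nitrogen gives a 1.0-fold higher number from compound 1 to compound 3 (0.02 log units; within the scatter) and thus no separation between the two rings. This position therefore takes a six-membered aromatic ring of carbon only as readily as the sulfur-containing five-membered ring, the first read on this group. No measurement on hand bears on why the two rings read alike. Open, from the compounds shown here alone, is whether an amine, a carboxylic acid or a saturated ring such as morpholine at this position would move the number beyond the scatter.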